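The source may hold more compounds than are shown below. What is called first, only, known or untested is meant among the compounds shown, and "the series" means these compounds.

Measured so far:
compound 1, `COc1cc(C)cc(-c2c(-c3ccnc(-c4ccc(N(C)C)cc4)c3)cnn2CC#N)c1`: -31%
compound 2, `COc1cc(C)cc(-c2nn(CC#N)cc2-c2ccnc(-c3ccc(N(C)C)cc3)c2)c1`: 1%
compound 3, `COc1cc(C)cc(-c2nn(CC#N)cc2-c2ccc(-c3cccc(C(C)=O)c3)nc2)c1`: 8%

In a functional assay on RPMI8266 cells (Homo sapiens) for cytotoxicity, read by sulforhodamine B assay, with a stated time of 48 h, tested at 1 uM (on this read-out higher numbers stand for a weaker effect at the one concentration tested and lower numbers for a stronger effect), compound 2 gives 1%, the second highest of the three numbers. Its nearest neighbour is compound 3 at 8%, a gap within the scatter, so the two cannot be ordered. Compound 1, at -31%, lies furthest away, beyond the scatter, and shows the stronger effect of that pair.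

Compound 4, `Cc1cc(O)cc(-c2nn(CC#N)cc2-c2ccnc(-c3ccc(N(C)C)cc3)c2)c1`, differs from compound 2 by a single change: hydrogen in place of methyl on an oxygen on an aromatic ring. Going by the values given here, no pair of measured compounds shows this change, so its effect in this assay is unknown here. Compound 4 is expected to stay close to compound 2, with an expected step of a number 1 percentage points higher from compound 2 to compound 4 (within the scatter) not beyond the scatter in either direction. The estimate for compound 4 in this assay is 2%, expected to fall between -18% and 22%.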

Compound 4, a percentage reported as activity, at one concentration (the size of the read-out at that concentration, not a potency): 15%
Compound 4: middle estimate off by 13 percentage points, on the low side; the range from low to high includes it.
By their numbers in this assay, from the lowest: compound 1; then compounds 2, 3 and 4 (each within the scatter of the next, the first and the last beyond it).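

In this assay, replacing methoxy with hydroxy on the 3-methoxy-5-methylphenyl group gives a number 14 percentage points higher from compound 2 to compound 4 (beyond the scatter), a modestly weaker effect at the one concentration tested. The earlier compounds shown here all carried the methoxy, so they could not show that this oxygen's methyl has any bearing on the read-out. No measurement offered here explains the step. From the compounds shown here alone, whether an ethoxy group or an amine at this place would restore or strengthen the effect remains open. So does whether the same change would act alike on the cores of compound 1 and compound 3.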